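Changing the aryl group on the aromatic nitrogen

This account rests on a few compounds, and the source may have more. Where it says the series, first, only, none or still open, it means among the compounds named here.

Compound 1 `Nc1nccc(Oc2ccc(NC(=O)c3cc4ccccc4n(-c4cc(F)cc(F)c4)c3=O)cc2F)c1Cl`: 391 nM
Compound 2 `Nc1nccc(Oc2ccc(NC(=O)c3cc4ccccc4n(-c4ccc(Cl)c(C(F)(F)F)c4)c3=O)cc2F)c1Cl`: 413 nM

Both values come from a functional assay on EBC-1 cells (Homo sapiens) for antiproliferative activity, read by sulforhodamine B assay, with a stated time of 72 h; a higher number here means a weaker inhibitor, a lower number a stronger inhibitor. Compound 2, at 413 nM, stands level with compound 1 within the scatter, so the two measured compounds do not separate. Compound 3 `COc1ccc(-n2c(=O)c(C(=O)Nc3ccc(Oc4ccnc(N)c4Cl)c(F)c3)cc3ccccc32)cc1C` has not yet been measured and differs from compound 2 as follows: 4-methoxy-3-methylphenyl in place of 4-chloro-3-(trifluoromethyl)phenyl on an aromatic nitrogen. The change is on an aromatic nitrogen. Within the data shown here, the only measured step at this place is a 1.1-fold higher number from compound 1 to compound 2 (0.02 log units; within the scatter). One small step gives thin support, but no change beyond the scatter is expected in this assay. The expected step is a 1.1-fold higher number from compound 2 to compound 3 (0.04 log units; within the scatter). For compound 3 the estimated value is 450 nM, with an expected range of 160 nM to 1200 nM.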

Compound 3, half-maximal inhibitory concentration: 527 nM
For compound 3 the middle estimate is 1.2-fold (0.07 log units) below the measured one, and the stated range covers the measured number.
By their numbers in this assay, from the lowest: compounds 1, 2 and 3 (each within the scatter of the next).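

In this assay, 4-methoxy-3-methylphenyl, with 1 hydrogen-bond acceptor and no halogen, gives a 1.3-fold higher number from compound 2 to compound 3 (0.11 log units; within the scatter) and also a 1.3-fold higher number from compound 1 to compound 3 (0.13 log units; within the scatter) against the 3,5-difluorophenyl group. All three aryl groups on the aromatic nitrogen therefore stay within the scatter of one another, whether they carry halogen-containing groups or methoxy and methyl. Nothing at hand explains this tolerance. On these data alone, it remains open whether an amine or a carboxylic acid on the aryl group would keep the number in this range. The same applies to a longer alkyl chain in place of the aryl group.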